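The source may hold more compounds than are shown below. What is called first, only, known or untested is meant among the compounds shown, and "the series" means these compounds.

Measured compounds in this series:

compound 1 `O=C(O[C@H]1C[C@H](n2cc(F)c(=O)[nH]c2=O)O[C@@H]1COP(=O)(O)Oc1ccccc1)c1ccccc1` — 5860 nM
compound 2 `O=C(O[C@H]1C[C@H](n2cc(F)c(=O)[nH]c2=O)O[C@@H]1COP(=O)(O)Oc1cccnc1)c1ccccc1` — 6900 nM
compound 3 `O=c1[nH]c(=O)n([C@H]2C[C@H](O)[C@@H](COP(=O)(O)Oc3ccccc3)O2)cc1F` — 15200 nM

In a functional assay on HeLa cells (Homo sapiens) for cytotoxicity, read by MTT assay, with a stated time of 48 h (on this read-out lower numbers stand for stronger inhibition and higher numbers for weaker inhibition), compound 3 gives the highest number of the three. Its step from compound 1 is a 2.6-fold higher number from compound 1 to compound 3 (0.41 log units; beyond the scatter), and the number for compound 3 also lies above that of compound 2, whose value is 6900 nM.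

Compound 4 `O=c1[nH]c(=O)n([C@H]2C[C@H](O)[C@@H](COP(=O)(O)Oc3cccnc3)O2)cc1F` is the next member. Against compound 3 the change is pyridin-3-yl in place of phenyl on an oxygen. Going by the values given here, one measured step bears on this exchange directly: among the benzoyl-bearing pair the same change gave a 1.2-fold higher number from compound 1 to compound 2 (0.07 log units; within the scatter), a step that stays inside the scatter. Among the compounds with values here, no other pair in the set tests this change, so the expectation rests on that single step. On this basis no step beyond the scatter is expected from compound 3 to compound 4 in this assay, and the expected step is a 1.2-fold higher number from compound 3 to compound 4 (0.07 log units; within the scatter). The estimate for compound 4 in this assay is therefore 18000 nM, with a range from 9000 nM to 36000 nM.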

Compound 4, half-maximal inhibitory concentration: 700 nM
Compound 4: the middle estimate sits 26-fold (1.41 log units) above what was measured, and the stated range ends above it.
By their numbers in this assay, from the lowest: compound 4; then compounds 1 and 2 (each within the scatter of the next); then compound 3.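

In this assay, going by these compounds alone, the effect of pyridin-3-yl in place of phenyl on an oxygen whose other neighbours are phosphorus depends on the rest of the molecule: without the benzoyl group the exchange gives a 22-fold lower number from compound 3 to compound 4 (1.34 log units; beyond the scatter), and the benzoyl-bearing pair shows no such step: the same change on two cores in this assay, a 1.2-fold higher number (0.07 log units; within the scatter) from compound 1 to compound 2 and a 22-fold lower number (1.34 log units; beyond the scatter) from compound 3 to compound 4, 26-fold (1.41 log units) apart, beyond the scatter of two such steps. The loss of benzoyl also changes direction with the aromatic group, as the pyridin-3-yl pair shows a 9.9-fold lower number from compound 2 to compound 4 (0.99 log units; beyond the scatter), whereas the phenyl pair moved the opposite way: the same change on two cores in this assay, a 2.6-fold higher number (0.41 log units; beyond the scatter) from compound 1 to compound 3 and a 9.9-fold lower number (0.99 log units; beyond the scatter) from compound 2 to compound 4, 26-fold (1.41 log units) apart, beyond the scatter of two such steps. The two changes therefore do not add independently in these four compounds, and the low number appears only where pyridin-3-yl and the free hydroxyl occur together.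

From the compounds shown here alone, whether pyridin-4-yl on the same oxygen keeps this low number remains open. Going by these compounds, it is also open whether an acetyl group in place of benzoyl cancels it as benzoyl does.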